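The compounds below may be only part of what the source reports. "The series", "measured", "known", "first", "only" and "open" are said of these compounds alone.

Measured compounds:
compound 1 `NC(=O)Cn1c(-c2ccc(Cl)cc2)nc2cccnc21` gives 4.1 mg/kg in a functional assay on the whole organism with Mus musculus as the target; a higher number here means that more compound is needed for the effect, a lower number that less compound is needed
compound 2 `CCN(CC)C(=O)Cn1c(-c2ccc(Cl)cc2)nc2cccnc21` gives 16 mg/kg in this assay
compound 3 `O=C(Cn1c(-c2ccc(Cl)cc2)nc2cccnc21)N1CCCCC1` gives 56.2 mg/kg in this assay

Compound 3 stands at the highest number of the three. Its nearest neighbour is compound 2, a 3.5-fold higher number from compound 2 to compound 3 (0.55 log units; beyond the scatter); furthest is compound 1, a 14-fold higher number from compound 1 to compound 3 (1.14 log units; beyond the scatter). The remaining step, a 3.9-fold higher number from compound 1 to compound 2 (0.59 log units; beyond the scatter), runs in the same direction.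

Compound 4 `O=C(Cn1c(-c2ccc(Cl)cc2)nc2cccnc21)Nc1ccccn1` is not yet measured. Relative to compound 3 the change is (pyridin-2-yl)amino in place of piperidin-1-yl on a carbonyl carbon. Both steps that end at compound 3 bear on it: from compound 1 the piperidin-1-yl raised the number by a large amount, and from compound 2 by a modest amount. Compound 4 returns to a group carrying a hydrogen-bond donor on the carbonyl carbon, as compound 1 does, though the group is larger than the amino of compound 1 and is aromatic. A lower number than compound 3 is therefore expected, probably landing between compound 1 and compound 3 rather than at compound 1 itself; the expected step is a 4.7-fold lower number from compound 3 to compound 4 (0.67 log units; beyond the scatter). Compound 4 is estimated at 12 mg/kg, with a range from 4 mg/kg to 40 mg/kg.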

Compound 4, dose for half-maximal effect: 100 mg/kg
Compound 4: the middle estimate sits 8.3-fold (0.92 log units) below what was measured; the measured number lies above the stated range.
By their numbers in this assay, from the lowest: compound 1; then compound 2; then compounds 3 and 4 (each within the scatter of the next).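

In this assay, a hydrogen-bond donor on the carbonyl carbon does not by itself keep the number near that of compound 1: (pyridin-2-yl)amino in place of piperidin-1-yl gives a 1.8-fold higher number from compound 3 to compound 4 (0.25 log units; within the scatter), so these two groups cannot be told apart here. Pyridin-2-yl in place of hydrogen on the amide-type nitrogen gives a 24-fold higher number from compound 1 to compound 4 (1.39 log units; beyond the scatter), and (pyridin-2-yl)amino in place of diethylamino gives a 6.3-fold higher number from compound 2 to compound 4 (0.80 log units; beyond the scatter), so all three groups larger than amino, with or without the amide hydrogen, go with higher numbers than compound 1. No measurement shown here accounts for these steps.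

From the compounds shown here alone, it remains open whether a single methyl on the amide nitrogen would stay close to compound 1 or move towards compound 2. Also open, going by these compounds, is whether phenylamino would match compound 4.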